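Swapping a methyl for chloro on the anilide ring

The source may report more compounds than this note shows. Statements on the series, on what has been measured and on what is new or still open speak of the compounds shown alone.

Measured so far:
- compound 1, `COc1cc2c(Nc3nc4ccc(C(=O)Nc5c(C)cccc5Cl)cc4s3)ncnc2cc1OCCCN1CCC(C)CC1`: 9700 nM
- compound 2, `COc1cc2c(Nc3nc4ccc(C(=O)Nc5c(C)cc(C)cc5C)cc4s3)ncnc2cc1OCCCN1CCCC1`: 8900 nM
- compound 3, `COc1cc2c(Nc3nc4ccc(C(=O)Nc5c(C)cccc5C)cc4s3)ncnc2cc1OCCCN1CCCC1`: 83800 nM

All three were tested in a functional assay on A549 cells (Homo sapiens) for cytotoxicity, read by WST assay, with a stated time of 72 h; a higher number here means a weaker inhibitor, a lower number a stronger inhibitor. Compound 3 stands highest of the three numbers, so it is the weakest inhibitor shown; compound 1 is the nearest to it and compound 2 the furthest, both well beyond the scatter. For the measured compounds named here, the one step between neighbours that was measured, a 9.4-fold higher number from compound 2 to compound 3 (0.97 log units; beyond the scatter), came from hydrogen in place of methyl on an aromatic carbon and weakened inhibition clearly.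

Compound 4, `COc1cc2c(Nc3nc4ccc(C(=O)Nc5c(C)cccc5Cl)cc4s3)ncnc2cc1OCCCN1CCCC1`, keeps the core and the pyrrolidine-bearing chain of compound 3 and differs only in this: chloro in place of methyl on an aromatic carbon. Going by the values given here, no measured step covers this exact exchange. What bears on it is that the 2-chloro-6-methylphenyl group of compound 4 also sits, on a different amine tail, in compound 1, and compound 1 gives 9700 nM, far lower than compound 3 with its 2,6-dimethylphenyl group. The step is therefore expected to run toward stronger inhibition, roughly an 8.4-fold lower number from compound 3 to compound 4 (0.92 log units; beyond the scatter), landing compound 4 at an estimated 10000 nM in this assay, most likely between 4000 nM and 30000 nM.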

Compound 4, half-maximal inhibitory concentration: 38600 nM
Beside the measured number, compound 4's estimate is 3.9-fold (0.59 log units) below it, outside the stated range (above it).
By their numbers in this assay, from the lowest: compounds 2 and 1 (each within the scatter of the next); then compound 4; then compound 3.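

In this assay, chloro in place of methyl on this aromatic carbon does lower the number, with a 2.2-fold lower number from compound 3 to compound 4 (0.34 log units; beyond the scatter), but the change does not bring compound 4 down to the level of the compound with the 2,4,6-trimethylphenyl group, as a 4.3-fold higher number from compound 2 to compound 4 (0.64 log units; beyond the scatter) shows. The amine tail now stands out as a second place that matters: with the 2-chloro-6-methylphenyl group held fixed, pyrrolidin-1-yl in place of 4-methylpiperidin-1-yl gives a 4.0-fold higher number from compound 1 to compound 4 (0.60 log units; beyond the scatter), so the low number of compound 1 cannot be credited to the chloro alone. Nothing measured here explains why either change moves the number as it does.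

Still open, on these data alone, is how a 2,6-dimethylphenyl group would behave on the 4-methylpiperidin-1-yl tail, which would show whether the exchange of methyl for chloro gives a step of similar size there. Also open, as far as these compounds go, is what fluoro, bromo or methoxy would do on this aromatic carbon, and what a morpholine at the end of the chain would do to the number.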